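The source may hold more compounds than are shown below. What is called first, only, known or untested is meant among the compounds shown, and "the series" means these compounds.

Working notes on the series, read in a functional assay on PC-3 cells (Homo sapiens) for cytotoxicity; a higher number here means a weaker inhibitor, a lower number a stronger inhibitor. Compound 1 (`O=C(CCCCC(=O)Nc1nc2ccc([N+](=O)[O-])cc2s1)NO`) gives > 30 ug/mL, which is a limit of the assay and not a number. Going by the values given here, compound 2 (`CCOc1ccc2nc(NC(=O)CCCCC(=O)NO)sc2c1`) gives 6.69 ug/mL, the only value that is not a limit, so it has no numerical neighbour to be ranked against.

Compound 3 (`O=C(CCCCC(=O)Nc1nc2ccccc2s1)NO`) differs from compound 2 at one place: hydrogen in place of ethoxy on an aromatic carbon. Among the compounds with values here, only one measured step bears on this change: an at least 4.4-fold lower number from compound 1 to compound 2 (0.65 log units; beyond the scatter), with ethoxy in place of nitro on an aromatic carbon. Going by these compounds, that step rests on (the limit of > 30 ug/mL in this assay, at which 1 of the 2 values shown sits), so its full size is unknown. It does show that a change at this carbon can move the read-out in this assay beyond the scatter. Hydrogen itself has not been measured there, so compound 3 is expected to fall short of compound 2 only modestly, towards a higher number. The expected change is a 2.2-fold higher number from compound 2 to compound 3 (0.35 log units; beyond the scatter), close to the edge of the scatter. The estimated value for compound 3 is 15 ug/mL, with an expected range of 5 ug/mL to 30 ug/mL.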

Compound 3, half-maximal inhibitory concentration: 12.5 ug/mL
Compound 3: middle estimate off by 1.2-fold (0.08 log units), on the high side; low and high end bracket the measured number.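

In this assay, this aromatic carbon now has a reading with hydrogen as well as with ethoxy: a 1.9-fold higher number from compound 2 to compound 3 (0.27 log units; within the scatter). Ethoxy and hydrogen therefore cannot be told apart here, so the earlier step from nitro to ethoxy does not show that ethoxy itself brings a gain; among the three groups, only nitro stands apart from the other two, as the second new step also shows: an at least 2.4-fold lower number from compound 1 to compound 3 (0.38 log units; beyond the scatter). The reading for compound 1 is a limit of the assay and not a number, so the full size of both steps from compound 1 remains unknown: the limit of > 30 ug/mL in this assay, at which 1 of the 3 values shown sits.

The compounds shown leave open whether an amine or a carboxylic acid on this aromatic carbon would stay level with hydrogen and ethoxy or separate from them as nitro does. They also leave open whether a longer chain in place of the one shared by all three compounds would move the read-out in this assay beyond the scatter.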